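The source may report more compounds than this note shows. Statements on the series, on what has been measured and on what is new or still open speak of the compounds shown alone.

Measured compounds:
Compound 1 `COc1ccc(N/C=C\C(=O)c2nc(-c3ccc(F)cc3)n3ccccc23)cc1`: in a functional assay on HCT-116 cells (Homo sapiens) for cytotoxicity, read by MTT assay, with a stated time of 48 h (on this read-out higher numbers stand for weaker inhibition and lower numbers for stronger inhibition), compound 1 gives > 30000 nM, a limit of the assay.
Compound 2 `O=C(/C=C\Nc1ccc(F)cc1)c1nc(-c2ccc(C(F)(F)F)cc2)n2ccccc12`: compound 2 gives > 30000 nM, again a limit.
Compound 3 `O=C(/C=C\Nc1cnc2ccccc2c1)c1nc(-c2ccc(C(F)(F)F)cc2)n2ccccc12`: compound 3 gives > 30000 nM, also a limit.

Compound 3 therefore stands only at a limit; no number is known for it, and the same holds for both other values shown (the limit of > 30000 nM in this assay, at which 3 of the 3 values shown sit). Within the data shown here, the single step between measured compounds, a step that the two limits leave unreadable from compound 2 to compound 3, cannot be read in size or direction for the same reason.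

Compound 4 `COc1ccc(N/C=C\C(=O)c2nc(-c3ccc(C(F)(F)F)cc3)n3ccccc23)cc1` differs from compound 3 by 4-methoxyphenyl in place of quinolin-3-yl on an amine nitrogen. Among the measured compounds shown here, the (4-methoxyphenyl)amino group that enters is the one carried by compound 1, which also sits at the limit. For the measured compounds named here, no measured step bears readably on this change, so no step beyond the scatter can be expected in this assay; the step that the limit leaves unreadable from compound 3 to compound 4 is estimated to be unreadable, since compound 3 offers only a limit > 30000 nM.

Compound 4 is expected to give about 45000 nM, in a range from 15000 nM to 150000 nM, most likely reported again as a limit.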

Compound 4, half-maximal inhibitory concentration: 7720 nM
The estimate for compound 4 lay 5.8-fold (0.77 log units) above the measured number, outside the stated range (below it).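

In this assay, 4-methoxyphenyl in place of quinolin-3-yl on the amine nitrogen gives an at least 3.8-fold lower number from compound 3 to compound 4 (0.58 log units; beyond the scatter), and methoxy in place of fluoro on an aromatic carbon gives an at least 3.8-fold lower number from compound 2 to compound 4 (0.58 log units; beyond the scatter). The (4-methoxyphenyl)amino group does not bring a measurable number on its own: with it held fixed, trifluoromethyl in place of fluoro on an aromatic carbon gives an at least 3.8-fold lower number from compound 1 to compound 4 (0.58 log units; beyond the scatter). Compound 4 is thus the only compound shown with a number rather than a limit, and each of its one-change partners remains at the limit: the limit of > 30000 nM in this assay, at which 3 of the 4 values shown sit.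

As far as these compounds go, the true size of all three steps stays open, and the step between compound 2 and compound 3 cannot be read. Also open, from the compounds shown here alone, is whether ethoxy or hydroxy in place of methoxy, or chloro in place of trifluoromethyl, would keep a measurable number.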